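Fluoro on the phenylpiperazine of compound 1

A few compounds are considered here, and "the series" means these few. Any claim that something is new, unique, unknown or untested is made for them only; others in the source may bear on it.

Compound 1 `Cc1nc(-c2ccccc2)c(C(=O)N2CCN(c3ccccc3)CC2)o1` gives 39.1 nM in a functional assay on HL-60 cells (Homo sapiens) for inhibition, read by MTT assay, with a stated time of 72 h (a lower number here means a stronger inhibitor, a higher number a weaker inhibitor), the lowest of the two numbers recorded so far. Compound 2 `CCc1nc(-c2ccc(F)cc2)c(C(=O)N2CCN(c3cccc(OC)c3)CC2)o1` differs from compound 1 in more than one place. In this assay compound 2 gives 411 nM, a higher number that lies beyond the usual scatter; no single-point comparison between the two is available. Compound 3 `Cc1nc(-c2ccccc2)c(C(=O)N2CCN(c3ccc(F)cc3)CC2)o1` has not been measured. It differs from compound 1 by fluoro in place of hydrogen on an aromatic carbon, the same change read one bond further out being phenyl to 4-fluorophenyl. Going by the values given here, nothing among the measured compounds isolates this change. A step of small size is expected, in either direction, most likely none beyond the scatter, so the expected step is a 1.3-fold higher number from compound 1 to compound 3 (0.11 log units; within the scatter). The estimate for compound 3 in this assay is 50 nM, within a range from 18 nM to 140 nM.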

Compound 3, half-maximal inhibitory concentration: > 1000 nM
Compound 3: only a limit was reported; the forecaster's own chance of this, stated with the estimate: 2%; at least 20-fold (1.30 log units) between middle value and limit.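

In this assay, this aromatic carbon, para to a large group, does not tolerate every replacement of hydrogen: swapping hydrogen for fluoro, a single heavy atom, gives an at least 25-fold higher number from compound 1 to compound 3 (1.40 log units; beyond the scatter). Going by these compounds alone, the change from phenyl to 4-fluorophenyl is therefore the first single-place change to show a large effect on the number. For compound 3, > 1000 nM is a limit and not a number, so the full size of the step cannot be read: the limit of > 1000 nM in this assay, at which 1 of the 3 values shown sits.

The compounds shown do not tell whether this result is specific to fluoro or extends to other replacements of hydrogen at this place, such as chloro or an amine. They also leave open whether a carboxylic acid or a longer chain at this place would give a number nearer that of compound 1.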